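The source may hold more compounds than are shown below. What is called first, only, known or untested is meant among the compounds shown, and "the series" means these compounds.

Compound 1 `CC/C=C\C(=O)Nc1cc(Nc2nccc(-c3cn(C)c4ccc(F)cc34)n2)c(OC)cc1N(C)CCN(C)C` gives 5290 nM in a functional assay on HepG2 cells (Homo sapiens) for antiproliferative activity, read by MTT assay, with a stated time of 72 h; on this read-out higher numbers stand for weaker inhibition and lower numbers for stronger inhibition. Compound 2 `CCC/C=C\C(=O)Nc1cc(Nc2nccc(-c3cn(C)c4ccc(F)cc34)n2)c(OC)cc1N(C)CCN(C)C` gives 3400 nM in this assay, a step of a 1.6-fold lower number from compound 1 to compound 2 (0.19 log units; within the scatter) for the change (methyl in place of hydrogen on a saturated chain carbon, two bonds along the chain from a double-bonded chain carbon). Compound 3 `CC/C=C\C(=O)Nc1cc(Nc2ncc(C#N)c(-c3cn(C)c4ccc(F)cc34)n2)c(OC)cc1N(C)CCN(C)C` gives 5880 nM in this assay; its core differs from the core of compound 1 by cyano in place of hydrogen on an aromatic carbon, a step of a 1.1-fold higher number from compound 1 to compound 3 (0.05 log units; within the scatter). Compound 4 `COc1cc(N(C)CCN(C)C)c(NC(=O)/C=C\C(C)C)cc1Nc1ncc(C#N)c(-c2cn(C)c3ccc(F)cc23)n1` carries the same kind of change on the core of compound 3, (methyl in place of hydrogen on a saturated chain carbon bound to a double-bonded chain carbon and a saturated chain carbon); here the methyl enters on a saturated chain carbon bound to a double-bonded chain carbon and a saturated chain carbon, rather than two bonds along the chain from a double-bonded chain carbon. A step of a 1.3-fold lower number from compound 3 to compound 4 (0.12 log units; within the scatter) is expected, resting on a 1.6-fold lower number from compound 1 to compound 2 (0.19 log units; within the scatter) on the other core, a step that itself lies within the scatter. Compound 4 is therefore estimated at 4500 nM in this assay, with a range from 2300 nM to 9000 nM.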

Compound 4, half-maximal inhibitory concentration: 2840 nM
Estimate against measurement, compound 4: 1.6-fold (0.20 log units) above; the range from low to high includes it.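

In this assay the added methyl gives a 2.1-fold lower number from compound 3 to compound 4 (0.32 log units; beyond the scatter) on the core of compound 3, a modest gain in inhibition. Set beside the earlier step, this shows no difference between the two cores that stands out from the scatter: the same change on two cores in this assay, a 1.6-fold lower number (0.19 log units; within the scatter) from compound 1 to compound 2 and a 2.1-fold lower number (0.32 log units; beyond the scatter) from compound 3 to compound 4, 1.3-fold (0.12 log units) apart, within the scatter of two such steps. Within the data shown here, it does not establish a rule for carrying the change across cores, since it rests on just two pairs, only one step lies beyond the scatter, and the methyl enters at a different chain carbon in each.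

The compounds shown leave open how the 3-methylbut-1-en-1-yl chain behaves on the core of compound 1. They also leave open whether a longer chain, a cyclopropyl ring or an amine at this chain end would follow the same course.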